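The compounds below may be only part of what the source reports. "The series", "measured", "known", "first", "only" and "open" are said of these compounds alone.

Measured so far:
- compound 1, `CC1=C(C(=O)OC(C)(C)C)C(c2cccs2)NC(=O)N1`: 38%
- compound 2, `CC1=C(C(=O)NC(C)C)C(c2ccco2)NC(=O)N1`: 2%
- compound 3, `CC1=C(C(=O)NC(C)C)C(c2ccoc2)NC(=O)N1`: 3%

In an assay on membranes from HEK293 cells for displacement of a labelled ligand from adenosine receptor A2b (Homo sapiens), read by scintillation counting, with a stated time of 30 min, tested at 1 uM (on this read-out lower numbers stand for less inhibition and higher numbers for more inhibition at the one concentration tested (going by the name of the read-out)), compound 3 stands second highest of the three numbers. Its nearest neighbour is compound 2, which gives 2%, within the scatter of compound 3. Furthest off is compound 1, which gives 38%, well beyond the scatter of compound 3. Compound 1 also carries a tert-butyl ester where compounds 2 and 3 carry an isopropylcarbamoyl group, so its higher number cannot be tied to the aromatic ring alone.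

Compound 4 is `CC1=C(C(=O)NC(C)C)C(c2cccs2)NC(=O)N1`. It differs from compound 3 as follows: thiophen-2-yl in place of furan-3-yl on a saturated ring carbon.

For the measured compounds named here, only one measured step concerns the aromatic ring on the saturated ring carbon: a number 1 percentage points higher from compound 2 to compound 3 (within the scatter). That step was within the scatter, so moving between the two furan attachment points changed nothing of note. Going by the values given here, no measured step swaps furan for thiophene while holding the isopropylcarbamoyl group fixed; the values of compound 1 and compound 3 show the two rings only across a second change. Compound 4 is therefore expected to give a number near compound 3, with a small rise possible, a number 7 percentage points higher from compound 3 to compound 4 (within the scatter). The estimate for compound 4 in this assay is 10%, with a range from 0% to 30%.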

Compound 4, a percentage reported as inhibition, at one concentration (the size of the read-out at that concentration, not a potency): 40%
Compound 4: middle estimate off by 30 percentage points, on the low side, outside the stated range (above it).
By their numbers in this assay, from the lowest: compounds 2 and 3 (each within the scatter of the next); then compounds 1 and 4 (each within the scatter of the next).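

Working notes on the saturated ring carbon: with the isopropylcarbamoyl group held fixed, thiophen-2-yl stands clearly apart from both furans in this assay, with a number 37 percentage points higher from compound 3 to compound 4 (beyond the scatter) and a number 38 percentage points higher from compound 2 to compound 4 (beyond the scatter). Thus, the aromatic ring at this position can matter a great deal, even though the swap leaves the heavy-atom count, the hydrogen-bond counts and the ring size unchanged, with one oxygen exchanged for one sulfur. On the carbonyl carbon, with thiophen-2-yl held fixed, isopropylamino in place of tert-butoxy gives a number 2 percentage points higher from compound 1 to compound 4 (within the scatter), so this pair shows no separation between the amide and the ester, and nothing available accounts for the gap between the thiophen-2-yl and furan compounds.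

Open, as far as these compounds go, is whether thiophen-3-yl or a plain phenyl ring on this carbon would read like thiophen-2-yl or like the furans, which would show how far the result extends beyond this one ring. Also open, from the compounds shown here alone, is whether a furan paired with the tert-butoxy ester stays at the level of the furan amides, and whether a longer chain or a cyclic amine on the carbonyl carbon keeps the number seen with thiophen-2-yl.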